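This account rests on a few compounds, and the source may have more. Where it says the series, first, only, none or still open, it means among the compounds named here.

Measured compounds in a functional assay on CHO cells with adenosine receptor A1 (Homo sapiens) as the target, read by cAMP accumulation and immunoassay, with a stated time of 6 min, tested at 10 uM; a lower number here means a stronger effect, a higher number a weaker effect of the compound at the concentration tested:
- compound 1 `COc1ccc(N2CCN(Cc3csc(N)c3C(=O)c3ccc(Cl)cc3)CC2)cc1` gives -52%
- compound 2 `Nc1scc(CN2CCN(c3ccc(F)c(F)c3)CC2)c1C(=O)c1ccc(Cl)cc1` gives -87%
- compound 3 `Nc1scc(CN2CCN(CCCc3ccc(Cl)cc3)CC2)c1C(=O)c1ccc(Cl)cc1` gives -76%

Compound 3 stands second highest of the three numbers; its nearest neighbour is compound 2 and its furthest is compound 1, both gaps lying beyond the scatter. Compound 4 `Nc1scc(CN2CCN(c3ccccc3Cl)CC2)c1C(=O)c1ccc(Cl)cc1` has not yet been measured. It differs from compound 3 in one place: 2-chlorophenyl in place of 3-(4-chlorophenyl)propyl on an amine nitrogen in a ring.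

Among the compounds with values here, the steps that bear on this are the two that exchange the group on the same ring nitrogen: a number 24 percentage points lower from compound 1 to compound 3 (beyond the scatter) and a number 11 percentage points higher from compound 2 to compound 3 (beyond the scatter). The two phenyl-bearing compounds lie on either side of compound 3, the 4-methoxyphenyl compound higher and the 3,4-difluorophenyl compound lower. Within the data shown here, the 2-chlorophenyl of compound 4 is again a halogen-bearing phenyl on that nitrogen, closer in kind to compound 2 than to compound 1, so a modest downward step is expected, a number 6 percentage points lower from compound 3 to compound 4 (within the scatter), with wide uncertainty since only two such phenyl compounds are known. Compound 4 is therefore estimated at -82%, in the range -100% to -58%.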

Compound 4, a percentage reported as activity, at one concentration (the size of the read-out at that concentration, not a potency): -18%
The estimate for compound 4 lay 64 percentage points below the measured number; measured number outside the range, above it.
By their numbers in this assay, from the lowest: compound 2; then compound 3; then compound 1; then compound 4.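

In this assay, within the data shown here, the exchange on the ring nitrogen has a wider reach than the earlier compounds showed: a number 58 percentage points higher from compound 3 to compound 4 (beyond the scatter), a number 69 percentage points higher from compound 2 to compound 4 (beyond the scatter) and a number 34 percentage points higher from compound 1 to compound 4 (beyond the scatter), which leaves compound 4 with the weakest effect of the four. A halogen on a phenyl ring carried directly by that nitrogen therefore does not by itself go with a low number: compound 2 fits such a reading, compound 4 goes against it, and compound 1, with no halogen on that phenyl ring, lies between them. No measurement at hand accounts for the gap between these two halogen-bearing phenyl groups.

Compound 2 and compound 4 differ in both the halogen and its place on the phenyl ring, so these compounds cannot separate the two. Going by these compounds, whether a plain phenyl, a 2-fluorophenyl or a benzyl group on that nitrogen would fall nearer compound 2 or compound 4 also stays open.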